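Stability of the pyridyl-for-hydroxyphenyl swap on two chains

A few compounds are considered here, and "the series" means these few. Any claim that something is new, unique, unknown or untested is made for them only; others in the source may bear on it.

Compound 1 `CC(C)(C)C1=C(C(=O)O)N2C(=O)[C@H]([C@@H](O)c3ccc(O)cc3)[C@H]2O1` carries 4-hydroxyphenyl on a saturated chain carbon bound to an oxygen on a saturated carbon and a saturated ring carbon; in an ADME assay, in phosphate buffer, at 28 degrees C, at pH 7.0 (a higher number here means that the compound lasts longer, a lower number that the compound disappears faster), compound 1 gives 10.3 h. Compound 2 `CC(C)(C)C1=C(C(=O)O)N2C(=O)[C@H]([C@@H](O)c3ccncc3)[C@H]2O1` is its pyridin-4-yl counterpart, and in this assay compound 2 gives 6 h. The change pyridin-4-yl in place of 4-hydroxyphenyl on a saturated chain carbon bound to an oxygen on a saturated carbon and a saturated ring carbon made a 1.7-fold lower number from compound 1 to compound 2 (0.23 log units; within the scatter). Compound 3 `CC(C)(C)C1=C(C(=O)O)N2C(=O)[C@H]([C@@H](O)CCc3ccc(O)cc3)[C@H]2O1` carries the 4-hydroxyphenyl group on a saturated chain carbon three bonds along the chain from that oxygen; the difference between its core and that of compound 1 is not broken down here. In this assay compound 3 gives 21.2 h, the highest of the three numbers and beyond the scatter from both compound 1 and compound 2. Compound 4 `CC(C)(C)C1=C(C(=O)O)N2C(=O)[C@H]([C@@H](O)CCc3ccncc3)[C@H]2O1` is not yet measured. It relates to compound 3 by pyridin-4-yl in place of 4-hydroxyphenyl on a saturated chain carbon, three bonds along the chain from an oxygen on a saturated carbon and a saturated ring carbon; this is the same kind of change as that from compound 1 to compound 2, but the place differs, the group sitting three bonds along the chain from the oxygen rather than on the chain carbon bound to it. Among the compounds with values here, on the strength of the single earlier step of a 1.7-fold lower number from compound 1 to compound 2 (0.23 log units; within the scatter), a step of about a 1.7-fold lower number from compound 3 to compound 4 (0.23 log units; within the scatter) is expected in this assay. Compound 4 is accordingly estimated at 12.5 h, with a plausible span from 7 h to 22 h.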

Compound 4, half-life: 15.8 h
Beside the measured number, compound 4's estimate is 1.3-fold (0.10 log units) below it, within the range that was stated.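

In this assay, pyridin-4-yl in place of 4-hydroxyphenyl gives steps on the two cores that cannot be told apart: the same change on two cores in this assay, a 1.7-fold lower number (0.23 log units; within the scatter) from compound 1 to compound 2 and a 1.3-fold lower number (0.13 log units; within the scatter) from compound 3 to compound 4, 1.3-fold (0.11 log units) apart, within the scatter of two such steps

Within the data shown here, this shows agreement between only two pairs, and because each step lies within the scatter, including a 1.3-fold lower number from compound 3 to compound 4 (0.13 log units; within the scatter), it gives no firm size or direction for the change and no rule for other cores. The change of chain is a separate matter: 2-(pyridin-4-yl)ethyl in place of pyridin-4-yl gives a 2.6-fold higher number from compound 2 to compound 4 (0.42 log units; beyond the scatter), beyond the scatter, whereas 2-(pyridin-4-yl)ethyl in place of 4-hydroxyphenyl gives a 1.5-fold higher number from compound 1 to compound 4 (0.19 log units; within the scatter), which does not separate that pair.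

Still open, as far as these compounds go, is whether the agreement holds for other groups at the end of the chain, such as an amine or a carboxylic acid in place of pyridin-4-yl. From the compounds shown here alone, a longer chain carrying pyridin-4-yl or 4-hydroxyphenyl is equally open.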